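The compounds below may be only part of what the source reports. "The series", "measured", "known", "first", "only" and "open" are said of these compounds alone.

In a functional assay on HBL-100 cells (Homo sapiens) for inhibition, read by sulforhodamine B assay, with a stated time of 48 h (on this read-out higher numbers stand for weaker inhibition of growth and lower numbers for stronger inhibition of growth), compound 1 `O=C(/C=C/c1ccc(Cl)cc1Cl)c1ccccc1` gives 17000 nM, compound 2 `O=C(/C(=C/C1CCCCC1)CCl)c1ccccc1` gives 22000 nM and compound 3 `O=C(/C(=C/c1ccccc1)CCl)c1ccccc1` gives 12000 nM. Compound 2 thus stands at the top of the three numbers, yet its gap to compound 1 and its gap to compound 3 are both within the scatter, so the three compounds cannot be told apart on this read-out. Going by the values given here, the one single-point step available, a 1.8-fold lower number from compound 2 to compound 3 (0.26 log units; within the scatter), exchanges the group on the double-bonded chain carbon and likewise stays within the scatter.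

Compound 4 `CC(=O)OC/C(=C\C1CCCCC1)C(=O)c1ccccc1` differs from compound 2 by acetoxy in place of chloro on a saturated chain carbon bound to a double-bonded chain carbon. Among the compounds with values here, no measured pair touches the chloromethyl group, so the series offers no direct precedent for this exchange; the only measured step concerns another part of the molecule and falls within the scatter, and all three numbers sit close together. For this assay the expectation is therefore no step beyond the scatter, an estimated no change at the digits printed from compound 2 to compound 4 (within the scatter). Compound 4 is expected at 22000 nM, with a range from 8000 nM to 60000 nM that reflects the absence of any tested analogue of this change.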

Compound 4, concentration for 50% growth inhibition: 21000 nM
For compound 4 the middle estimate is 1.0-fold (0.02 log units) above the measured one; the range from low to high includes it.
By their numbers in this assay, from the lowest: compounds 3, 1, 4 and 2 (each within the scatter of the next).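

In this assay, going by these compounds alone, acetoxy in place of chloro on a saturated chain carbon bound to a double-bonded chain carbon gives a 1.0-fold lower number from compound 2 to compound 4 (0.02 log units; within the scatter), the first reading at this position, and compound 2 and compound 4 cannot be told apart. The exchange of chloromethyl for acetoxymethyl replaces a single chlorine with a group of 4 heavy atoms and 2 hydrogen-bond acceptors, yet the step stays within the scatter, so in this cyclohexyl-bearing pair the read-out does not separate chloro from acetoxy. No evidence at hand bears on this result.

Open, as far as these compounds go, is whether a hydroxyl group or an amine in place of chloro at this carbon would give a step beyond the scatter. Also open, from the compounds shown here alone, is whether the exchange for acetoxy reads the same with phenyl in place of cyclohexyl, as in compound 3.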